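Removing the Phenyl from an Inactive Urea Series

The compounds below may be only part of what the source reports. "The series", "measured", "known", "first", "only" and "open" are said of these compounds alone.

Compound 3 `O=C(Nc1ccc(C(F)(F)F)cc1)N1CCN(c2ccc(-c3ccccc3)nn2)CC1` is the starting point. In an assay on HEK293 cells for inhibition of transient receptor potential cation channel subfamily V member 1 (Homo sapiens), read by FLIPR, at pH 5.5 (a higher number here means a weaker inhibitor, a lower number a stronger inhibitor), compound 3 reaches only the assay limit of > 10000 nM. Compound 1 `Cc1ccc(N2CCN(C(=O)Nc3ccc(C(F)(F)F)cc3)CC2)nn1` likewise sits at the limit, giving > 10000 nM in this assay. Compound 2 `CC(C)c1ccc(NC(=O)N2CCN(c3ccc(-c4ccccc4)nn3)CC2)cc1` also stops at the limit with > 10000 nM. The two measured steps, a step that the two limits leave unreadable from compound 1 to compound 3 and a step that the two limits leave unreadable from compound 2 to compound 3, remain unreadable because of the limit of > 10000 nM in this assay, at which 3 of the 3 values shown sit. Compound 4 `O=C(Nc1ccc(C(F)(F)F)cc1)N1CCN(c2cccnn2)CC1` differs from compound 3 by hydrogen in place of phenyl on an aromatic carbon. For the measured compounds named here, no measured step bears on this particular change, so neither a direction nor a size can be read from the data. Compound 4 is therefore expected to remain at the limit, and the step that the limit leaves unreadable from compound 3 to compound 4 is estimated to stay within the scatter. The expected value for compound 4 is 20000 nM, with a range from 5000 nM to 100000 nM.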

Compound 4, half-maximal inhibitory concentration: > 10000 nM
Compound 4 gave a limit, no number; the forecaster's own chance of this, stated with the estimate: 85%; the middle value lies beyond the limit too.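

For the compounds shown here, no step to compound 4 can be read, either from compound 3 or from compound 1, because all the results are limits rather than numbers: the limit of > 10000 nM in this assay, at which 4 of the 4 values shown sit. Going by these compounds, how strongly any of the four compounds inhibits in this assay stays open.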